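This account rests on a few compounds, and the source may have more. Where it says the series, first, only, none or still open, it means among the compounds named here.

In a functional assay on MDA-MB-231 cells (Homo sapiens) for inhibition, read by MTT assay, with a stated time of 96 h (a higher number here means a weaker inhibitor of growth, a lower number a stronger inhibitor of growth), compound 2 `C=CCOC(=O)SCCCCCCNC(=O)c1cc(-c2ccncc2)n[nH]1` gives 36000 nM and compound 1 `O=C(NCCCCCCSSCCCCCCNC(=O)c1cc(-c2ccncc2)n[nH]1)c1cc(-c2ccncc2)n[nH]1` gives 27300 nM, two numbers that lie within the scatter of each other. Compound 3 `CCCCCCCC/C=C\CCCCCCCC(=O)SCCCCCCNC(=O)c1cc(-c2ccncc2)n[nH]1` reads > 50000 nM, which is a limit of the assay and not a number. Among the measured compounds shown here, all three therefore sit in a weak range of growth inhibition, and no measured pair differs in one place only, so the series offers no direct precedent for the next change.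

Compound 4 `CC(=O)SCCCCCCNC(=O)c1cc(-c2ccncc2)n[nH]1` differs from compound 2 by one substitution, methyl in place of allyloxy on a carbonyl carbon. For the measured compounds named here, with no measured step to scale this change, the expectation in this assay starts from compound 2 at 36000 nM, with no shift beyond the scatter in either direction. The expected size of the change is a 1.2-fold lower number from compound 2 to compound 4 (0.08 log units; within the scatter). For compound 4 the estimated value is 30000 nM, with an expected range of 13000 nM to 50000 nM.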

Compound 4, concentration for 50% growth inhibition: > 50000 nM
Compound 4 ended at the assay's limit; the forecaster's own chance of this, stated with the estimate: 20%; middle value at least 1.6-fold (0.22 log units) from the limit.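

In this assay, among the compounds shown here, methyl in place of allyloxy on a carbonyl carbon whose other neighbour is sulfur gives the only one-place step: an at least 1.3-fold higher number from compound 2 to compound 4 (0.14 log units; that floor lies within the scatter). For compound 4, > 50000 nM is a limit of the assay and not a number, so the step has a floor but no measured size. Acetyl brings no gain in growth inhibition over allyloxycarbonyl at this position, and any loss cannot be sized further with the read-out capped: the limit of > 50000 nM in this assay, at which 2 of the 4 values shown sit.

As far as these compounds go, it remains open whether compound 4 lies just past the limit or far past it. From the compounds shown here alone, it is also open whether a group carrying an amine or a carboxylic acid in place of allyloxy would bring the number clear of the limit.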